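The compounds below may be only part of what the source reports. "The series", "measured", "known", "first", "only" and "open" are said of these compounds alone.

Working notes on a small series built on one shared core. Compound 1 `NCCCCN(C[C@@H]1Cc2ncccc2CN1)[C@H]1CCCc2cccnc21`, compound 2 `NCCCCN(C[C@@H]1Cc2nccnc2CN1)[C@H]1CCCc2cccnc21` and compound 3 `NC(=O)NCCCCN(C[C@H]1Cc2ncccc2CN1)[C@H]1CCCc2cccnc21` have been measured; compound 4 `c1cnc2c(c1)CN[C@@H](CN(CCCCNC1COC1)[C@H]1CCCc3cccnc31)C2` has not. In an ADME assay for permeability, using PAMPA, with a stated time of 4 h, at pH 7.4 (on this read-out lower numbers stand for lower permeability and higher numbers for higher permeability), compound 1 gives 7 nm/s. In this assay compound 2 gives 2 nm/s, and in the same read-out compound 3 gives 2 nm/s. Compound 3 stands level with compound 2 at the digits given, the two within the scatter of each other and together the lowest of the three numbers; compound 1 is the furthest from compound 3, its number higher by a margin beyond the scatter. No two of the measured compounds differ in one place only, so no single-change step can be read among them.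

Compound 4 differs from compound 3 in one place: oxetan-3-yl in place of carbamoyl on an amine nitrogen. For the measured compounds named here, no measured pair shows this change, so its effect has to be estimated from the series as a whole. A modest step upward in this assay is expected, a 3.0-fold higher number from compound 3 to compound 4 (0.48 log units; beyond the scatter), on the thought that compound 1 with 7 nm/s shows what this core has reached so far. Compound 4 is therefore expected to give about 6 nm/s in this assay, with a range from 2 nm/s to 20 nm/s.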

Compound 4, apparent permeability: 300 nm/s
The estimate for compound 4 lay 50-fold (1.70 log units) below the measured number; the whole stated range lies below it.
By their numbers in this assay, from the lowest: compounds 2 and 3 (each within the scatter of the next); then compound 1; then compound 4.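

In this assay, for the compounds shown here, oxetan-3-yl in place of carbamoyl on an amine nitrogen gives a 150-fold higher number from compound 3 to compound 4 (2.18 log units; beyond the scatter), the first single-change step that can be read and a large one. Going by these compounds alone, with the shared core and the rest of the chain held constant, this step shows that the group carried on this nitrogen can, on its own, shift the read-out well beyond the scatter, something the earlier compounds, none of which differ in one place only, could not show. No measurement here bears on what lies behind the step, so it stands as an observation about this one pair of groups.

A single pair leaves open whether the ring, its oxygen or the loss of the carbamoyl group carries the step, and cyclobutyl, tetrahydrofuran-3-yl, methyl or acetyl on the same nitrogen would help to separate these readings. It also leaves open whether the same change gives a step of similar size on the core of compound 2.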